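The compounds below may be only part of what the source reports. "The series", "measured", "known", "first", "only" and "open" are said of these compounds alone.

Measured so far in a functional assay on NCI-H661 cells (Homo sapiens) for inhibition, read by MTT assay, with a stated time of 72 h; a lower number here means a stronger inhibitor of growth, a higher number a weaker inhibitor of growth:
Compound 1, `CN(C)/C=N/c1c(C=O)c(-c2ccc(Cl)cc2)nn1-c1ccccc1`, gives 8600 nM.
Compound 2, `CN(C)/C=N/c1c(C=O)c(C(C)(C)C)nn1-c1ccccc1`, gives 42800 nM.
Compound 3, `CN/C=N/c1cc(-c2ccccc2)nn1-c1ccccc1`, gives only a limit of this assay, > 50000 nM, not a number.

Compound 3 thus stands at the limit of > 50000 nM in this assay, at which 1 of the 3 values shown sits. It is the weakest point of the three shown, and no number is attached to it. For the measured compounds named here, compound 1 and compound 2 both carry the dimethylformamidine and the aldehyde; the only computed step among them, a 5.0-fold higher number from compound 1 to compound 2 (0.70 log units; beyond the scatter), concerns the exchange on the other ring carbon, not the amidine.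

Compound 4, `C/C(=N\c1cc(-c2ccccc2)nn1-c1ccccc1)N(C)C`, differs from compound 3 by a group of 6 heavy atoms (4 carbon, 2 nitrogen; no ring) in place of a group of 4 heavy atoms (2 carbon, 2 nitrogen; no ring), on an aromatic carbon. Going by the values given here, no measured pair varies the amidine alone, so that step does not bear directly on this change, and nothing points to a gain from it. The expectation is therefore a number no higher from compound 3 to compound 4 (the limit leaves the size open), no movement beyond the scatter. Compound 4 is expected to give 50000 nM, with a range from 15000 nM to 150000 nM, and a fair chance that this assay again returns only a limit.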

Compound 4, concentration for 50% growth inhibition: 35100 nM
The estimate for compound 4 lay 1.4-fold (0.15 log units) above the measured number; measured number inside the range.
By their numbers in this assay, from the lowest: compound 1; then compounds 4 and 2 (each within the scatter of the next). At a limit, above all of these: compound 3.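

In this assay, the group of 6 heavy atoms in place of the group of 4 heavy atoms on this aromatic carbon gives an at least 1.4-fold lower number from compound 3 to compound 4 (0.15 log units; that floor lies within the scatter). Compound 4 is the one compound shown that carries a number without the aldehyde, so the core does not need that group to give a value below the limit of the assay. The size of the step stays unknown because compound 3 carries only a limit of the assay, not a number: the limit of > 50000 nM in this assay, at which 1 of the 4 values shown sits.

From the compounds shown here alone, whether a piperidine ring in place of the dimethylamino part, or a longer chain on the amidine carbon, would move the number beyond the scatter remains open. No pair shown varies the aldehyde alone, so its own contribution also remains open.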